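The source may report more compounds than this note shows. Statements on the series, on what has been measured and on what is new or still open speak of the compounds shown alone.

Measured compounds:
Compound 1 `Nc1scc(-c2cccc(C(F)(F)F)c2)c1C(=O)c1ccccc1`: 59%
Compound 2 `Nc1scc(-c2ccc(F)cc2)c1C(=O)c1ccccc1`: 60%

In a functional assay on CHO cells for agonist activity at adenosine receptor A1 (Homo sapiens), read by fluorescence and ERK phosphorylation, with stated times of 30 min and 1.5 h, tested at 10 uM (on this read-out lower numbers stand for a weaker effect and higher numbers for a stronger effect at the one concentration tested), compound 1 gives 59% while compound 2 gives 60%. Compound 2 is the one with the larger of the two readings, though its difference from compound 1 lies within the scatter, so the two cannot be told apart. Among the compounds with values here, no pair of measured compounds differing in a single place is available, so no measured step can be drawn on.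

Compound 3 `Nc1scc(-c2ccc(I)cc2)c1C(=O)c1ccccc1` has not yet been measured. It differs from compound 2 in one place: iodo in place of fluoro on an aromatic carbon. The shared core and the remainder of the structure are untouched. Compound 1, which carries a different group on that ring, gives 59%, at the same level as compound 2, which gives no sign of wide swings from changes on this ring. The step from compound 2 to compound 3 is expected to be a number 2 percentage points lower from compound 2 to compound 3 (within the scatter), none beyond the scatter. For compound 3 the estimated value is 58%, within a range of 40% to 75%.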

Compound 3, a percentage reported as activity, at one concentration (the size of the read-out at that concentration, not a potency): 50%
Compound 3: the middle estimate sits 8 percentage points above what was measured; the range from low to high includes it.
By their numbers in this assay, from the lowest: compounds 3, 1 and 2 (each within the scatter of the next).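

In this assay, within the data shown here, the change from 4-fluorophenyl to 4-iodophenyl offers the first comparison of compounds that differ in one place, and the reading falls by a number 10 percentage points lower from compound 2 to compound 3 (within the scatter) and so does not separate the two compounds. Iodo and fluoro, on an aromatic carbon para to a large group, therefore cannot be told apart at the one concentration tested, although this step sits at the edge of what the scatter allows. No measurement shown here offers an explanation for this result.

From the compounds shown here alone, whether an amine, a carboxylic acid or a methoxy group at this position would move the reading beyond the scatter remains open. So does whether the same change from fluoro to iodo would give a similar step on a different core or at another place on the ring.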